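This account rests on a few compounds, and the source may have more. Where it says the series, first, only, none or still open, it means among the compounds named here.

Measured so far: compound 1 `CCNC(=O)CC1CCc2cc(OC)c(OC)cc21` gives 15.6%; compound 2 `CCCCNC(=O)CC1CCc2cc(OC)c(OC)cc21` gives 31.3%.

Among the measured compounds shown here, in a functional assay on the whole organism (strain Wistar) for inhibition, with Rattus norvegicus as the target, read by paw edema, with stated times of 60 min and 1 h, at a dose of 100 mg/kg by the oral route (a higher number here means more inhibition at the dose given (going by the name of the read-out), a lower number less inhibition), compound 2 stands highest of the two numbers, its only neighbour being compound 1, separated by a number 15.7 percentage points higher from compound 1 to compound 2 (beyond the scatter). Compound 3 `CCCCCCNC(=O)CC1CCc2cc(OC)c(OC)cc21` differs from compound 2 by ethyl in place of hydrogen on a saturated chain carbon, four bonds along the chain from an amide-type nitrogen. For the measured compounds named here, the single step that bears on this is the same change placed two bonds along the chain from the amide-type nitrogen, a number 15.7 percentage points higher from compound 1 to compound 2 (beyond the scatter), a modest gain beyond the scatter. A further rise in this assay of comparable or somewhat smaller size is therefore expected, with the caution that one step alone gives no assurance the pattern holds. The expected step is a number 8.7 percentage points higher from compound 2 to compound 3 (within the scatter). For compound 3 the estimate is 40%, ranging from 22% to 58%.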

Compound 3, a percentage reported as inhibition, in the whole organism at one dose (the size of the read-out at that dose, not a potency): 47.6%
Compound 3: middle estimate off by 7.6 percentage points, on the low side; low and high end bracket the measured number.
By their numbers in this assay, from the lowest: compound 1; then compound 2; then compound 3.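

In this assay, ethyl in place of hydrogen four bonds along the chain from the amide-type nitrogen gives a number 16.3 percentage points higher from compound 2 to compound 3 (beyond the scatter) and so extends the gain of a number 15.7 percentage points higher from compound 1 to compound 2 (beyond the scatter) seen with the same change two bonds along the chain. Taken as one change, butyl in place of hydrogen two bonds along the chain gives a number 32 percentage points higher from compound 1 to compound 3 (beyond the scatter) and none of the compounds shown goes against this rise. Nothing available explains the rise.

On these data alone, whether a longer chain continues the rise remains open. So does how a chain ending in an amine or a carboxylic acid would compare.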